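Side chain change from compound 3 to compound 4

This account rests on a few compounds, and the source may have more. Where it says the series, first, only, none or still open, it means among the compounds named here.

Measured in a functional assay on T47D cells (Homo sapiens) for cytotoxicity, read by colorimetric assay and MTT assay; on this read-out higher numbers stand for weaker inhibition and lower numbers for stronger inhibition:
- compound 1 `COc1cccc2cc(-c3ccccc3)c(O)nc12`: 10000 nM
- compound 2 `CCN(CC)C(=O)Cn1c(=O)c(-c2ccc(OC)cc2)cc2c(OC)cc(OC)cc21`: 10000 nM
- compound 3 `COc1ccc(-c2cc3c(OC)cc(OC)cc3n(CC(=O)OCc3ccccc3)c2=O)cc1`: 10000 nM

Compound 1 and compound 2 stand level with compound 3 at 10000 nM. The next compound is compound 4 `COc1ccc(-c2cc3c(OC)cc(OC)cc3n(CCC#N)c2=O)cc1`, and the change lies on a saturated chain carbon bound to an aromatic nitrogen: cyanomethyl in place of benzyloxycarbonyl on a saturated chain carbon bound to an aromatic nitrogen. Cut one bond further out, the same difference reads (benzyloxycarbonyl)methyl to 2-cyanoethyl.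

Among the measured compounds shown here, only one measured step bears on this side chain: no change at the digits printed from compound 2 to compound 3 (within the scatter), with benzyloxy in place of diethylamino on a carbonyl carbon. That step kept the carbonyl, whereas here the whole benzyloxycarbonyl leaves, so it covers the change only in part. For the measured compounds named here, no measured compound carries a cyanomethyl group. On this evidence, no step beyond the scatter is expected in this assay, and no direction can be favoured. The expected outcome is no change at the digits printed from compound 3 to compound 4 (within the scatter). For compound 4 the estimated value is 10000 nM, with an expected range of 4000 nM to 16000 nM.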

Compound 4, half-maximal inhibitory concentration: 10000 nM
Beside the measured number, compound 4's estimate shows no gap at the digits printed; the range from low to high includes it.
By their numbers in this assay, from the lowest: compounds 1, 2, 3 and 4 (each within the scatter of the next).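

In this assay the whole side chain on the saturated chain carbon bound to an aromatic nitrogen can be exchanged, not only the group on its carbonyl: cyanomethyl for benzyloxycarbonyl gives no change at the digits printed from compound 3 to compound 4 (within the scatter) and cyanomethyl for diethylcarbamoyl gives no change at the digits printed from compound 2 to compound 4 (within the scatter) in this series. Side chains with and without a carbonyl, and with and without an aromatic ring, therefore read alike here, so compounds 2, 3 and 4 show no order at this position. No measurement available gives a reason for this flat reading.

Still open, from the compounds shown here alone, is whether a carboxylic acid, a primary amine or a longer chain ending in a nitrile would separate from these three compounds at this position. Also open, going by these compounds, is whether a different side chain would read differently on a core with other methoxy substitution.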